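A few compounds are considered here, and "the series" means these few. Any claim that something is new, unique, unknown or untested is made for them only; others in the source may bear on it.

Three compounds of the series have been run in an assay on isolated protein for inhibition of hexokinase-2 (Rattus norvegicus), with a stated time of 6 h, tested at 10 mM; a higher number here means more inhibition at the concentration tested (going by the name of the read-out), a lower number less inhibition. Compound 1 `CN(CCCCN(C)C(=O)CCCNc1ncnc2c1ncn2[C@@H]1O[C@H](COP(=O)(O)OP(=O)(O)OP(=O)(O)O)[C@@H](O)[C@H]1O)C(=O)CCCNC(=O)CI` gives 0% in this assay. Compound 2 `O=C(CI)NCCCCNc1ncnc2c1ncn2[C@@H]1O[C@H](COP(=O)(O)OP(=O)(O)OP(=O)(O)O)[C@@H](O)[C@H]1O` gives 0%, and compound 3 `CN(CCCN(C)C(=O)CCCNc1ncnc2c1ncn2[C@@H]1O[C@H](COP(=O)(O)OP(=O)(O)OP(=O)(O)O)[C@@H](O)[C@H]1O)C(=O)CCCNC(=O)CI` gives 0%. Compound 2 therefore stands level with compound 1 and with compound 3 at the digits reported; all three values lie within the scatter of one another, and no ordering among them can be drawn from these numbers.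

Compound 4 `O=C(I)NCC(=O)NCCCCCCNc1ncnc2c1ncn2[C@@H]1O[C@H](COP(=O)(O)OP(=O)(O)OP(=O)(O)O)[C@@H](O)[C@H]1O` has not yet been measured. It differs from compound 2 in one place: a group of 10 heavy atoms (5 carbon, 2 nitrogen, 2 oxygen, 1 iodine; no ring) in place of a group of 5 heavy atoms (2 carbon, 1 nitrogen, 1 oxygen, 1 iodine; no ring), on a saturated chain carbon, four bonds along the chain from a nitrogen on an aromatic ring. The shared core is untouched by this replacement.

Among the measured compounds shown here, no step between two measured compounds is available to calibrate the change. Because compound 2 gives 0% in this assay, and compound 1 and compound 3 with other chain endings give the same reading, the expected step of no change at the digits printed from compound 2 to compound 4 (within the scatter) is none beyond the scatter. Compound 4 is accordingly estimated to give about 0% in this assay, expected to fall between 0% and 12%.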

Compound 4, a percentage reported as inhibition, at one concentration (the size of the read-out at that concentration, not a potency): 0%
Compound 4: the middle estimate sits on the measured number at the digits printed, within the range that was stated.
By their numbers in this assay, from the lowest: compounds 1, 2, 3 and 4 (each within the scatter of the next).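

Working notes: in this assay, the first step readable at this position, with a group of 10 heavy atoms replacing ((iodomethyl)carbonyl)amino on a saturated chain carbon, four bonds along the chain from a nitrogen on an aromatic ring, is no change at the digits printed from compound 2 to compound 4 (within the scatter). The entering group brings 2 hydrogen-bond donors and 2 hydrogen-bond acceptors in place of 1 of each, and compound 4 still gives 0%, so this larger replacement does not separate it from compound 2 at the concentration tested. No measurement is available to explain this result.

With all four readings level, the compounds shown do not establish whether any change at this position can alter the reading. On these data alone, it remains open whether a chain ending in an amine or a carboxylic acid in place of the iodine-bearing group would read differently.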